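The source may report more compounds than this note shows. Statements on the series, on what has been measured and on what is new or still open speak of the compounds shown alone.

Measured compounds:
compound 1, `Cc1cc(NC(=O)CC(=O)O)c2c(c1Oc1ccc(O)c(CC(C)C)c1)CCC2`: 39.9 nM
compound 2, `Cc1cc(NC(=O)CC(=O)O)c2c(c1Oc1ccc(O)c(CCc3ccc(F)cc3F)c1)CCC2`: 12 nM
compound 3, `Cc1cc(NC(=O)CC(=O)O)c2c(c1Oc1ccc(O)c(CCc3ccc(F)c(F)c3)c1)CCC2`: 6 nM

In an in vitro assay on cells for displacement of a labelled ligand from thyroid hormone receptor beta (Homo sapiens), with a stated time of 48 h (a lower number here means a stronger inhibitor, a higher number a weaker inhibitor), compound 3 carries the lowest of the three numbers, though one of its two gaps (a 2.0-fold lower number from compound 2 to compound 3 (0.30 log units; within the scatter)) sits within the scatter, while the other (a 6.7-fold lower number from compound 1 to compound 3 (0.82 log units; beyond the scatter)) lies beyond it. Compound 4, `Cc1cc(NC(=O)CC(=O)O)c2c(c1Oc1ccc(O)c(CCc3ccccc3Cl)c1)CCC2`, differs from compound 3 by 2-chlorophenyl in place of 3,4-difluorophenyl on a saturated chain carbon, two bonds along the chain from an aromatic carbon. Among the compounds with values here, the steps that bear on it, a 3.3-fold lower number from compound 1 to compound 2 (0.52 log units; beyond the scatter) and a 6.7-fold lower number from compound 1 to compound 3 (0.82 log units; beyond the scatter), both concern replacing isopropyl with a fluorinated benzyl, whereas the only swap of one ring pattern for another, a 2.0-fold lower number from compound 2 to compound 3 (0.30 log units; within the scatter), stays within the scatter. Within the data shown here, no measured step covers a 2-chlorophenyl, so compound 4 is expected to land near compound 3, a step of a 1.7-fold higher number from compound 3 to compound 4 (0.22 log units; within the scatter), with an estimated value of 10 nM, ranging from 4 nM to 25 nM.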

Compound 4, inhibition constant: 30 nM
Compound 4: the middle estimate sits 3.0-fold (0.48 log units) below what was measured, outside the stated range (above it).
By their numbers in this assay, from the lowest: compounds 3 and 2 (each within the scatter of the next); then compounds 4 and 1 (each within the scatter of the next).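

In this assay, the pattern on the ring at this position now makes a difference beyond the scatter: 2-chlorophenyl reads weaker than 3,4-difluorophenyl (a 5.0-fold higher number from compound 3 to compound 4 (0.70 log units; beyond the scatter)) and 2,4-difluorophenyl (a 2.5-fold higher number from compound 2 to compound 4 (0.40 log units; beyond the scatter)). The gain over isopropyl seen with both fluorinated rings does not extend to this ring, as the step to it stays within the scatter (a 1.3-fold lower number from compound 1 to compound 4 (0.12 log units; within the scatter)). Nothing available explains this difference. Going by these compounds, it remains open whether the chlorine itself or its place on the ring accounts for the result, and how an unsubstituted phenyl or a 3,4-dichlorophenyl would read.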